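A few compounds are considered here, and "the series" means these few. Any claim that something is new, unique, unknown or untested is made for them only; others in the source may bear on it.

The series shares a core, seen in compound 1 `COc1ccc(C2=C(c3cc(OC)c(OC)c(OC)c3)C(=O)C(OC(C)=O)C2)cc1`, compound 2 `C=CCOc1cc(C2=C(c3cc(OC)c(OC)c(OC)c3)C(=O)C(O)C2)ccc1OC` and compound 3 `COc1ccc(OC)c(C2=C(c3cc(OC)c(OC)c(OC)c3)C(=O)CC2O[SiH2]C(C)(C)C)c1`. In an ADME assay on HEK293 cells (Homo sapiens) for cytotoxicity, read by MTT assay, with a stated time of 72 h (on this read-out lower numbers stand for stronger inhibition and higher numbers for weaker inhibition), compound 1 has "not determined" (no result reported). Compound 3 gives 9.5 ug/mL in this assay. Compound 2 reaches only a limit of the assay, > 100 ug/mL. Among the numbers shown, compound 2 thus stands at the limit, with one further entry carrying no number at all. Compound 4 `COc1ccc(C2=C(c3cc(OC)c(OC)c(OC)c3)C(=O)C(O)C2)cc1NC(=O)c1ccccc1` differs from compound 2 by benzamido in place of allyloxy on an aromatic carbon. Among the compounds with values here, no measured step matches this change, so its size and direction are open. The step from compound 2 to compound 4 is expected to be an at least 1.6-fold lower number from compound 2 to compound 4 (0.22 log units; that floor lies within the scatter), toward somewhat stronger inhibition. Compound 4 is therefore estimated to give 60 ug/mL, within a range from 15 ug/mL to 150 ug/mL.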

Compound 4, half-maximal inhibitory concentration: > 100 ug/mL
Compound 4 was reported as a limit; the forecaster's own chance of this, stated with the estimate: 40%; middle value at least 1.6-fold (0.22 log units) from the limit.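

No step can be read between compound 2 and compound 4, because both stop at the same limit: the limit of > 100 ug/mL in this assay, at which 2 of the 4 values shown sit. The compounds shown leave open what benzamido in place of allyloxy on an aromatic carbon does to the number.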